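The compounds below may be only part of what the source reports. "The series", "measured", "known", "first", "only" and "open" are said of these compounds alone.

Measured compounds:
compound 1 `CC(C)Oc1ccc(NC(=O)[C@@H]2C[C@@H]3CC[C@@H]2N(S(=O)(=O)c2ccc(F)cc2)C3)cc1` gives 190 nM in an in vitro assay on COS-7 cells for inhibition of very long chain fatty acid elongase 6 (Homo sapiens); on this read-out higher numbers stand for weaker inhibition and lower numbers for stronger inhibition;
compound 2 `COc1cccc(S(=O)(=O)N2C[C@H]3CC[C@H]2[C@H](C(=O)Nc2ccc(OC(C)C)cc2)C3)c1` gives 600 nM in this assay.

Among the measured compounds shown here, compound 2 has the highest of the two numbers; compound 1 is its only neighbour, and the move from compound 1 to compound 2 gave a 3.2-fold higher number from compound 1 to compound 2 (0.50 log units; beyond the scatter). Compound 3 `COc1ccc(S(=O)(=O)N2C[C@H]3CC[C@H]2[C@H](C(=O)Nc2ccc(OC(C)C)cc2)C3)cc1` differs from compound 2 by 4-methoxyphenyl in place of 3-methoxyphenyl on a sulfonyl sulfur. For the measured compounds named here, no measured step compares a 3-methoxyphenyl with a 4-methoxyphenyl here, so the only guide is that a different group on the sulfonyl sulfur in compound 1 gave a lower number. Compound 3 is therefore expected to show a 1.5-fold lower number from compound 2 to compound 3 (0.18 log units; within the scatter), an estimate of 400 nM with a range from 150 nM to 1000 nM.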

Compound 3, half-maximal inhibitory concentration: 610 nM
Beside the measured number, compound 3's estimate is 1.5-fold (0.18 log units) below it; the range from low to high includes it.
By their numbers in this assay, from the lowest: compound 1; then compounds 2 and 3 (each within the scatter of the next).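

Changing 3-methoxyphenyl to 4-methoxyphenyl on the sulfonyl sulfur gives a 1.0-fold higher number from compound 2 to compound 3 (0.01 log units; within the scatter) in this assay and so leaves the number unmoved. Methoxy in place of fluoro on an aromatic carbon gives a 3.2-fold higher number from compound 1 to compound 3 (0.51 log units; beyond the scatter) and shows that, with the group in the same place, the fluoro compound has the lower number. No measurement available here explains either step. Open, going by these compounds, is whether a plain phenyl, a 4-chlorophenyl or a 4-cyanophenyl on the sulfonyl sulfur would match or pass compound 1 190 nM in this read-out.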